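The source may report more compounds than this note shows. Statements on the series, on what has been measured and on what is new or still open speak of the compounds shown alone.

Of the compounds shown here, three of one series have been tested in a functional assay on PANC-1 cells (Homo sapiens) for inhibition, read by MTT assay, with a stated time of 24 h, tested at 10 uM; on this read-out higher numbers stand for more inhibition at the one concentration tested (going by the name of the read-out) and lower numbers for less inhibition. Compound 1 `COc1ccc(OCCCOc2cc(=O)n(CCCO)c3c2CC(CC=C(C)C)C(C)(C)C3)cc1` gives 4.1% in this assay. Compound 2 `CC(C)=CCC1Cc2c(OCCCOc3ccc(Cl)cc3)cc(=O)n(CCCO)c2CC1(C)C` differs from compound 1 by chloro in place of methoxy on an aromatic carbon, and in this assay compound 2 gives 0%, a step of a number 4.1 percentage points lower from compound 1 to compound 2 (within the scatter). Compound 3 `COc1ccc(OCCCOc2cc(=O)n(CCCO)c3c2CC(C/C=C(\C)CCC=C(C)C)C(C)(C)C3)cc1` carries the other core, which differs from the core of compound 1 by 3-methylbut-2-en-1-yl in place of hydrogen on a saturated chain carbon bound to a double-bonded chain carbon; in this assay compound 3 gives 0%, a step of a number 4.1 percentage points lower from compound 1 to compound 3 (within the scatter). Compound 4 `CC(C)=CCC/C(C)=C/CC1Cc2c(OCCCOc3ccc(Cl)cc3)cc(=O)n(CCCO)c2CC1(C)C` has not yet been measured. It differs from compound 3 by chloro in place of methoxy on an aromatic carbon, the same change as that made from compound 1 to compound 2, at the same kind of place. Because the earlier step was a number 4.1 percentage points lower from compound 1 to compound 2 (within the scatter), the corresponding step in this assay is expected to be a number 1 percentage points higher from compound 3 to compound 4 (within the scatter). Compound 4 is therefore estimated to give 1%, expected to lie between 0% and 10%.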

Compound 4, a percentage reported as inhibition, at one concentration (the size of the read-out at that concentration, not a potency): 0%
Estimate against measurement, compound 4: 1 percentage points above, within the range that was stated.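

In this assay, chloro in place of methoxy gives no change at the digits printed from compound 3 to compound 4 (within the scatter), which matches the earlier step: the same change on two cores in this assay, a number 4.1 percentage points lower (within the scatter) from compound 1 to compound 2 and no change at the digits printed (within the scatter) from compound 3 to compound 4, 4.1 percentage points apart, within the scatter of two such steps

Adding 3-methylbut-2-en-1-yl gives no change at the digits printed from compound 2 to compound 4 (within the scatter), which likewise matches: the same change on two cores in this assay, a number 4.1 percentage points lower (within the scatter) from compound 1 to compound 3 and no change at the digits printed (within the scatter) from compound 2 to compound 4, 4.1 percentage points apart, within the scatter of two such steps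

So neither change is seen to depend on the core, but with all four compounds giving so little inhibition at the one concentration tested, this does not show that either change would carry over the same way in a compound with clear inhibition.

The compounds shown leave open how an amine or a carboxylic acid in place of methoxy or chloro would read here. From the compounds shown here alone, whether any such group would move the number beyond the scatter also remains open.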